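Dimethylamino in Place of Ethyl: Compound 3 Expected

The source may report more compounds than this note shows. Statements on the series, on what has been measured and on what is new or still open speak of the compounds shown alone.

Compound 2 `CCc1ccc(-c2cc(OC)cc(C(=O)Nc3nn[nH]n3)n2)cc1` stands lowest of the two compounds measured in a functional assay on the whole organism with Rattus norvegicus as the target, at a dose of 0.3 mg/kg by the oral route; a higher number here means a stronger effect of the compound at the dose given, a lower number a weaker effect; there compound 2 gives 23%, while compound 1 `Nc1ccc(-c2cc(Cl)cc(C(=O)Nc3nn[nH]n3)n2)cc1` gives 39%, a gap beyond the scatter. For the measured compounds named here, no pair differing in a single place has been measured, so the size of this kind of change is unknown. Compound 3 `COc1cc(C(=O)Nc2nn[nH]n2)nc(-c2ccc(N(C)C)cc2)c1` differs from compound 2 by dimethylamino in place of ethyl on an aromatic carbon. Compound 3 is expected to move upward by a number 9 percentage points higher from compound 2 to compound 3 (within the scatter), a modest step, because compound 1 reaches 39%. The estimate for compound 3 in this assay is 32%, within 15% to 50%.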

Compound 3, a percentage reported as inhibition, in the whole organism at one dose (the size of the read-out at that dose, not a potency): 29%
Compound 3: middle estimate off by 3 percentage points, on the high side; measured number inside the range.
By their numbers in this assay, from the lowest: compounds 2, 3 and 1 (each within the scatter of the next, the first and the last beyond it).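

In this assay, for the compounds shown here, the first step at a single place reads a number 6 percentage points higher from compound 2 to compound 3 (within the scatter) for dimethylamino in place of ethyl on an aromatic carbon, para to a large group. At this position, the exchange therefore does not separate the two compounds beyond the scatter. Nothing available bears on the reason for this result. The compounds shown leave open whether a longer chain such as propyl, or a carboxylic acid, on this same aromatic carbon would give a step beyond the scatter.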